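A Chloro Addition Where Only Limits Are Known

A few compounds are considered here, and "the series" means these few. Any claim that something is new, unique, unknown or untested is made for them only; others in the source may bear on it.

Compound 1 `O=C(Nc1cccc(-n2cc(-c3ccncc3)c(-c3ccc(Cl)c(O)c3)n2)c1)Nc1cccc(C(F)(F)F)c1` has no number in a functional assay on PC-3 cells (Homo sapiens) for inhibition, read by sulforhodamine B assay, with a stated time of 48 h; a lower number here means that less compound is tolerated, a higher number that more compound is tolerated: compound 1 gives > 32500 nM, which is a limit of the assay and not a measured value. Compound 2 `COc1cc(-c2nn(-c3cccc(NC(=O)Nc4cccc(C(F)(F)F)c4)c3)cc2-c2ccncc2)ccc1Cl` likewise gives only a limit in this assay, > 50000 nM. The step that the two limits leave unreadable from compound 1 to compound 2 therefore cannot be read. Compound 3 `O=C(Nc1cccc(-n2cc(-c3ccncc3)c(-c3ccc(Cl)c(O)c3)n2)c1)Nc1ccc(Cl)c(C(F)(F)F)c1` differs from compound 1 by chloro in place of hydrogen on an aromatic carbon. For the measured compounds named here, no measured step resembles this change, and the single measured step is unreadable, so compound 3 is expected to sit at a limit as well. Compound 3 is estimated at 40000 nM, within 12000 nM to 130000 nM. The expected step is a step that the limit leaves unreadable from compound 1 to compound 3.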

Compound 3, concentration lethal to 50% of the cells: > 32500 nM
Compound 3: no number, only a limit; the forecaster's own chance of this, stated with the estimate: 70%; the middle value is on the limit's open side.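

Compound 3, like compound 1, gives only a limit in this assay, so no step between compound 1 and compound 3 can be read: the limit of > 32500 nM in this assay, at which 2 of the 3 values shown sit.

The compounds shown leave open whether the added chloro changes the lethal concentration at all, and at what concentration any of the three compounds would reach a measured value.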